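A few compounds are considered here, and "the series" means these few. Any claim that something is new, unique, unknown or untested is made for them only; others in the source may bear on it.

Measured compounds in the series so far:

- compound 1, `CC(C)n1c(=O)n(C(=O)NC2CCNCC2)c2ccccc21`: in a functional assay on HEK293 cells for activation of 5-hydroxytryptamine receptor 4 (Homo sapiens), read by cAMP accumulation (on this read-out lower numbers stand for smaller maximal responses and higher numbers for larger maximal responses), compound 1 gives > 100%, which is a limit of the assay and not a number.
- compound 2, `CCN1CCC(NC(=O)c2cc(Cl)c(N)cc2OC)CC1`: in this assay compound 2 gives > 100%, again a limit.
- compound 3, `CCCCCN1CCC(NC(=O)c2cc(Cl)c(N)cc2OC)CC1`: in this assay compound 3 gives > 100%, also a limit.

Compound 3 therefore stands at the limit of this assay, and the same holds for every other value shown: the limit of > 100% in this assay, at which 3 of the 3 values shown sit. Among the compounds with values here, only one step between measured compounds differing in one place is available, a step that the two limits leave unreadable from compound 2 to compound 3, and with both ends sitting at the limit its size cannot be read.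

Compound 4, `COc1cc(N)c(Cl)cc1C(=O)NC1CCN(CCCCCCCCO)CC1`, differs from compound 3 by 3-hydroxypropyl in place of hydrogen on a saturated chain carbon, five bonds along the chain from an amine nitrogen in a ring. The change lengthens the same chain that was already lengthened from compound 2 to compound 3 and adds a hydroxyl at its end. Within the data shown here, no measured step bears on such a change in a readable way; the step from compound 2 to compound 3 merely shows that extending this chain did not pull the response below the limit.

Compound 4 is expected to reach the limit of this assay as well, so the step of a number no higher from compound 3 to compound 4 (the limit leaves the size open) is expected to be nothing beyond the scatter. The estimate for compound 4 in this assay is 100%, with a range from 85% to 115%.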

Compound 4, intrinsic activity: the largest response reached, in percent of the reference agonist's: > 100%
Compound 4 gave a limit, no number; the forecaster's own chance of this, stated with the estimate: 70%; the middle value lies on the limit itself.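

In this assay compound 4 gives > 100%, which is a limit and not a number. The steps from compound 2 and compound 3 to compound 4 cannot be read, since every value sits at the same limit: the limit of > 100% in this assay, at which 4 of the 4 values shown sit.

The compounds shown leave open how large each maximal response is, and whether changing the chain on the amine nitrogen in a ring alters it at all.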